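The source may hold more compounds than are shown below. What is called first, only, known or untested is meant among the compounds shown, and "the series" means these compounds.

Measured compounds:
- compound 1 `O=C(NO)c1ccc(CNc2nccc(-c3cccnc3)n2)cc1` — in an assay on isolated protein for inhibition of protein deacetylase HDAC6 (Homo sapiens), read by fluorescence, with stated times of 3 h and 60 min (on this read-out lower numbers stand for stronger inhibition and higher numbers for weaker inhibition), compound 1 gives 42 nM
- compound 2 `Nc1ccccc1NC(=O)c1ccc(CNC2=NC[C@H](c3ccccc3)S2)cc1` — in this assay compound 2 gives "not determined" (no result reported)

Among the measured compounds shown here, compound 1 is the only compound of the set with a number: its value in this assay stands alone, and compound 2, the anilide bearing a thiazoline on the benzylic amine, contributes no result at all. For the measured compounds named here, there is therefore no measured pair from which the size of a step can be read.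

Compound 3 `Nc1cc(C(=O)O)ccc1NC(=O)c1ccc(CNc2nccc(-c3cccnc3)n2)cc1` keeps the core of compound 1 and differs from it in one place: 2-amino-4-carboxyphenyl in place of hydroxy on an amide-type nitrogen. The amide that carried the hydroxy group now carries a 2-amino-4-carboxyphenyl ring instead.

With no anilide measured in this assay, the step from compound 1 to compound 3 cannot be anchored to any shown difference. The author nevertheless expects a step well beyond the scatter, toward weaker inhibition, written as a 190-fold higher number from compound 1 to compound 3 (2.28 log units; beyond the scatter). Compound 3 is accordingly estimated at 8000 nM, within a range from 1500 nM to 40000 nM, with a real chance that only a limit is reported.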

Compound 3, half-maximal inhibitory concentration: > 20000 nM
Compound 3: no number, only a limit; the forecaster's own chance of this, stated with the estimate: 35%; middle value at least 2.5-fold (0.39 log units) from the limit.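

Among the compounds shown here, on an amide-type nitrogen whose other neighbour is the carbonyl carbon, putting 2-amino-4-carboxyphenyl in place of hydroxy gives, in this assay, an at least 470-fold higher number from compound 1 to compound 3 (2.67 log units; beyond the scatter), which is large, beyond the scatter, and the first step in the set that can be read at all. For compound 3 the value > 20000 nM is a limit of the assay and not a number, so the step has a floor but no known upper end, and its full size stays unread. What the earlier compounds could not show is that inhibition in this assay responds strongly to what sits at this place, a reading that rests on one pair and on a single limit: the limit of > 20000 nM in this assay, at which 1 of the 3 values shown sits.

The change swaps a single hydroxy for a whole ring that carries both an amine and a carboxylic acid, so the compounds shown do not separate what each of these parts contributes to the step. From the compounds shown here alone, a plain phenyl ring on the same nitrogen, or a methyl ester in place of the carboxylic acid, would be needed to tell them apart, and whether any such group keeps a measurable number in this assay remains open.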